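Methoxy for Ethyl: Expected Half-Life of Compound 4

This account rests on a few compounds, and the source may have more. Where it says the series, first, only, none or still open, it means among the compounds named here.

Measured compounds:
compound 1 `CCc1nc(-c2ccc(OC)cc2C(F)(F)F)c(CC)nc1NC(CC)CC` gives 0.0717 h
compound 2 `CCC(CC)Nc1nc(OC)c(-c2ccc(Cl)cc2Cl)nc1OC` gives 0.0417 h
compound 3 `CCc1nc(-c2ccc(Cl)cc2Cl)c(OC)nc1NC(CC)CC` gives 0.183 h

These three compounds were studied in an in vitro ADME assay on microsomes (Rattus norvegicus) for metabolic stability; a lower number here means that the compound disappears faster, a higher number that the compound lasts longer. Compound 3 and compound 2 differ in one place: methoxy in place of ethyl on an aromatic carbon. That change gave a 4.4-fold lower number from compound 3 to compound 2 (0.64 log units; beyond the scatter). Compound 1 and compound 2 lie within the scatter of each other in this assay, while compound 3 lasts longer than compound 1. How the core of compound 1 differs from that of compound 3 is not broken down here.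

Compound 4 `CCc1nc(NC(CC)CC)c(OC)nc1-c1ccc(OC)cc1C(F)(F)F` has not yet been measured. It differs from compound 1 as follows: methoxy in place of ethyl on an aromatic carbon. Among the compounds with values here, this is the same kind of change as the one from compound 3 to compound 2, though its surroundings are not identical: in compound 1 the altered carbon is meta to a large group and para to an ethyl group, whereas in compound 3 it is meta to a 2,4-dichlorophenyl group and para to a methoxy group.

Within the data shown here, with only one earlier example of this change, the expectation for compound 4 rests on a 4.4-fold lower number from compound 3 to compound 2 (0.64 log units; beyond the scatter) applied to the value of compound 1, 0.0717 h, with a wide band to allow for the different surroundings. Compound 4 is therefore expected to show a step of a 2.9-fold lower number from compound 1 to compound 4 (0.46 log units; beyond the scatter) in this assay. The estimated half-life of compound 4 is 0.025 h, within a range from 0.008 h to 0.07 h.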

Compound 4, half-life: 2 h
Compound 4: the middle estimate sits 80-fold (1.90 log units) below what was measured; the whole stated range lies below it.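

In this assay, putting methoxy in place of ethyl on the aromatic carbon of the core of compound 1 gave a 28-fold higher number from compound 1 to compound 4 (1.45 log units; beyond the scatter), so here the change went with a longer half-life. Set beside the earlier example, the same change moved the number in opposite directions on the two cores, and the two steps differ by more than the scatter allows: the same change on two cores in this assay, a 4.4-fold lower number (0.64 log units; beyond the scatter) from compound 3 to compound 2 and a 28-fold higher number (1.45 log units; beyond the scatter) from compound 1 to compound 4, 120-fold (2.09 log units) apart, beyond the scatter of two such steps This shows that neither the size nor the direction of the step carried over from one core to the other in this series, but with only two examples it gives no rule for a third core and does not show which feature of the surroundings sets the outcome.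

The cores differ both in the aryl group and in the remaining substituent on the shared ring, and no pair shown changes only one of these, so which of them decides the direction of the step stays open. Also open, on these data alone, is how other groups on the same carbon would behave in this assay, such as a longer chain like propyl or an amine like dimethylamino.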